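A few compounds are considered here, and "the series" means these few. Any claim that something is new, unique, unknown or untested is made for them only; others in the source may bear on it.

Measured in a functional assay on KYSE-70 cells for antiproliferative activity against KYSE-70 cell line (Homo sapiens), read by MTT assay, with a stated time of 72 h; on this read-out higher numbers stand for weaker inhibition and lower numbers for stronger inhibition:
- compound 1 `O=C(Nc1ccc(Cl)cc1)c1cc(=O)[nH]c2cc(Br)ccc12`: > 20000 nM, a limit and not a number
- compound 2 `O=C(Nc1ccccn1)c1cc(=O)[nH]c2cc(Br)ccc12`: 11000 nM
- compound 3 `O=C(Nc1cccc(F)c1)c1cc(=O)[nH]c2cc(Br)ccc12`: 8900 nM

Compound 3 stands level with compound 2, as a 1.2-fold lower number from compound 2 to compound 3 (0.09 log units; within the scatter) shows. Compound 4 `COc1cccc(NC(=O)c2cc(=O)[nH]c3cc(Br)ccc23)c1` has methoxy in place of fluoro on an aromatic carbon, meta to a large group (methoxy in place of fluoro on an aromatic carbon). Among the compounds with values here, no measured step makes this exact change. The closest evidence is from swaps of the group on the amide-type nitrogen: a 1.2-fold lower number from compound 2 to compound 3 (0.09 log units; within the scatter) and, resting on a limit, an at least 2.2-fold lower number from compound 1 to compound 3 (0.35 log units; beyond the scatter). Those steps are small, so no shift beyond the scatter is expected, and the estimated step is a 1.1-fold higher number from compound 3 to compound 4 (0.05 log units; within the scatter). Compound 4 is expected at 10000 nM, within an estimated range of 4500 nM to 20000 nM.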

Compound 4, half-maximal inhibitory concentration: > 20000 nM
Compound 4 gave a limit, no number; the forecaster's own chance of this, stated with the estimate: 15%; at least 2.0-fold (0.30 log units) between middle value and limit.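

In this assay, methoxy in place of fluoro on this aromatic carbon, meta to a large group, gives an at least 2.2-fold higher number from compound 3 to compound 4 (0.35 log units; beyond the scatter). The earlier steps shown here swapped the whole group on the amide-type nitrogen, whereas this one changes a single substituent on that group and still moves the read-out beyond the scatter. The value of compound 4 is a limit, so the step gives only a floor: the limit of > 20000 nM in this assay, at which 2 of the 4 values shown sit.

On these data alone, whether hydroxy or methyl at this carbon would read like fluoro or like methoxy stays open. Also open, as far as these compounds go, is how an amine or a carboxylic acid would read there.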